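From compound 3 to compound 4: one side chain changes

This account rests on a few compounds, and the source may have more. Where it says the series, first, only, none or still open, it means among the compounds named here.

Measured so far in an ADME assay on microsomes from liver (Rattus norvegicus, strain Sprague-Dawley) for metabolic stability, read by LC-MS, using NADPH, with a stated time of 60 min, tested at 10 mM; on this read-out lower numbers stand for slow clearance and higher numbers for fast clearance:
compound 1 `O=Cc1c(-c2nc(NCCCCN3CCCC3)c3ccccc3n2)[nH]c2ccccc12` gives 2.8 mL.min-1.g-1
compound 2 `CN(C)CCCNc1nc(-c2[nH]c3ccccc3c2C=O)nc2ccccc12` gives 6.3 mL.min-1.g-1
compound 3 `CCN(CC)CCCCNc1nc(-c2[nH]c3ccc(OC)cc3c2C=O)nc2ccccc12` gives 2.7 mL.min-1.g-1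

Compound 3 at 2.7 mL.min-1.g-1 and compound 1 at 2.8 mL.min-1.g-1 lie within the usual scatter of each other, while compound 2 stands apart with the higher 6.3 mL.min-1.g-1 on this scale. The change to compound 4 `COc1ccc2[nH]c(-c3nc(NCCN4CCCC4)c4ccccc4n3)c(C=O)c2c1` is this: pyrrolidin-1-yl in place of 2-(diethylamino)ethyl on a saturated chain carbon, two bonds along the chain from a nitrogen on an aromatic ring on a saturated chain carbon, two bonds along the chain from a nitrogen on an aromatic ring. Within the data shown here, no measured step covers this exact change. The nearest, dimethylamino in place of (pyrrolidin-1-yl)methyl, gave a 2.3-fold higher number from compound 1 to compound 2 (0.35 log units; beyond the scatter) and was modest. Guided by that single step, the expected change in this assay is small and upward, namely a 1.5-fold higher number from compound 3 to compound 4 (0.17 log units; within the scatter) as estimated. Compound 4 is expected at 4 mL.min-1.g-1 (estimated range 2 mL.min-1.g-1 to 8 mL.min-1.g-1).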

Compound 4, intrinsic clearance in microsomes: 6.6 mL.min-1.g-1
Beside the measured number, compound 4's estimate is 1.7-fold (0.22 log units) below it; the range from low to high includes it.
By their numbers in this assay, from the lowest: compounds 3 and 1 (each within the scatter of the next); then compounds 2 and 4 (each within the scatter of the next).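

In this assay, the step from 4-(diethylamino)butyl to 2-(pyrrolidin-1-yl)ethyl on the methoxy-bearing core gave a 2.4-fold higher number from compound 3 to compound 4 (0.39 log units; beyond the scatter) and so moved the number beyond the scatter. Alongside a 2.3-fold higher number from compound 1 to compound 2 (0.35 log units; beyond the scatter) on the core without methoxy, it makes a second case in which a shorter amine-ending chain goes with a higher number, and no compound shown goes against this. Nothing measured here explains the rise. The compounds shown leave open whether the shorter chain or the ring accounts for it, as chain length and end group change together in this step. Going by these compounds, how a morpholine ring at the chain end would read also stays open.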